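Carrying a Chloro Step From One Core to Another

A few compounds are considered here, and "the series" means these few. Any claim that something is new, unique, unknown or untested is made for them only; others in the source may bear on it.

Measured so far in a functional assay on DLD-1 cells (Homo sapiens) for antiproliferative activity, read by CellTiter-Glo, with a stated time of 72 h; on this read-out higher numbers stand for weaker inhibition and lower numbers for stronger inhibition:
compound 1, `CC1CCN(C2CCN(S(=O)(=O)c3cccnc3)CC2)CC1`, gives 2400 nM
compound 2, `CC1CCN(C2CCN(S(=O)(=O)c3ccc(Cl)nc3)CC2)CC1`, gives 3700 nM
compound 3, `CC1CCN(C2CCN(S(=O)(=O)c3ccccc3-c3ccccc3)CC2)CC1`, gives 0.96 nM

Compound 1 and compound 2 share a core and differ by chloro in place of hydrogen on an aromatic carbon. That change made a 1.5-fold higher number from compound 1 to compound 2 (0.19 log units; within the scatter). Compound 3 stands on a different core; how the two cores differ is not broken down here, but the values show compound 3 far stronger than compound 1 and compound 2 in this assay.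

Compound 4, `CC1CCN(C2CCN(S(=O)(=O)c3ccccc3-c3ccc(Cl)cc3)CC2)CC1`, has not yet been measured. It differs from compound 3 by chloro in place of hydrogen on an aromatic carbon. This is the same kind of change as from compound 1 to compound 2, not the same: there the ring carried one nitrogen and the chloro sat next to the ring nitrogen, here the ring is of carbon only, though in both the chloro sits para to a large group.

Among the measured compounds shown here, the single earlier example rests on one pair and on a different core, so the expectation is loose. Compound 4 is expected to show a 1.6-fold higher number from compound 3 to compound 4 (0.19 log units; within the scatter), because the comparable change gave a 1.5-fold higher number from compound 1 to compound 2 (0.19 log units; within the scatter). Compound 4 is therefore estimated at 1.5 nM, with a likely range from 0.4 nM to 6 nM.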

Compound 4, half-maximal inhibitory concentration: 202 nM
Compound 4: middle estimate off by 130-fold (2.13 log units), on the low side, and the stated range ends below it.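

In this assay, chloro in place of hydrogen on an aromatic carbon gave a 210-fold higher number from compound 3 to compound 4 (2.32 log units; beyond the scatter), so a change that had left the number within the scatter on one core weakened inhibition sharply on the other. Among the compounds shown here, the two cores therefore answer differently to this change: the same change on two cores in this assay, a 1.5-fold higher number (0.19 log units; within the scatter) from compound 1 to compound 2 and a 210-fold higher number (2.32 log units; beyond the scatter) from compound 3 to compound 4, 140-fold (2.14 log units) apart, beyond the scatter of two such steps This shows that, within these compounds, the step on the core of compound 1 was no guide to the step on the core of compound 3, but with one pair on each core it does not show what sets the two steps apart or how the change would behave on a further core.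

The compounds shown leave open whether the weaker inhibition of compound 4 belongs to chloro itself or would come with any group in that place, such as fluoro, methyl or methoxy. They also leave open whether an amine or a carboxylic acid in that place would give a step of similar size.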